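A carboxy group enters where a methyl sat

The compounds below may be only part of what the source reports. "The series", "measured", "known", "first", "only" and "open" are said of these compounds alone.

Of the compounds shown here, two of a shared core have been measured so far. Compound 1 `O=C(/C=C/c1ccc2c(c1)B(O)OC2)c1ccco1` gives 24100 nM in a functional assay on HCT-116 cells (Homo sapiens) for cytotoxicity, read by MTT assay, with a stated time of 48 h; on this read-out lower numbers stand for stronger inhibition and higher numbers for weaker inhibition. Compound 2 `Cc1ccc(C(=O)/C=C/c2ccc3c(c2)B(O)OC3)cc1` gives 10500 nM in this assay, and it stands at the lowest of the two numbers, the nearest being compound 1, which lies at a higher number. For the measured compounds named here, the only step between measured compounds is a 2.3-fold lower number from compound 1 to compound 2 (0.36 log units; beyond the scatter), which comes with 4-methylphenyl in place of furan-2-yl on a carbonyl carbon.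

The next compound, compound 3 `O=C(O)c1ccc(C(=O)/C=C/c2ccc3c(c2)B(O)OC3)cc1`, differs from compound 2 by carboxy in place of methyl on an aromatic carbon. Going by the values given here, no measured step touches the group on that aromatic carbon: the one step recorded concerns the group attached to the carbonyl carbon, not the substituent para to the large group. The expectation for compound 3 therefore rests on little, and a step within the scatter is as likely as a modest shift in either direction. Compound 3 is estimated at 15000 nM in this assay, within a range from 5000 nM to 50000 nM. This estimate means an expected step of a 1.4-fold higher number from compound 2 to compound 3 (0.15 log units; within the scatter).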

Compound 3, half-maximal inhibitory concentration: > 100000 nM
Compound 3: no number, only a limit; the forecaster's own chance of this, stated with the estimate: 10%; middle value at least 6.6-fold (0.82 log units) from the limit.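

In this assay, the aromatic carbon para to a large group proves to be a place where the substituent matters: carboxy in place of methyl there gives an at least 9.5-fold higher number from compound 2 to compound 3 (0.97 log units; beyond the scatter), whereas the earlier compounds had shown only a change on the carbonyl carbon, a 2.3-fold lower number from compound 1 to compound 2 (0.36 log units; beyond the scatter). Compound 3 is read only as a limit, not as a number: the limit of > 100000 nM in this assay, at which 1 of the 3 values shown sits. The methyl of compound 2 therefore cannot be exchanged freely, since this single exchange leads from the lowest number shown to a result that no longer gives a number at all.

The compounds shown leave open whether this loss belongs to the carboxy group itself or would follow any group entering in place of methyl, and an amine, a methoxy group or the methyl ester of the same carboxylic acid at this place could separate these readings. They also give no reason for the step, and with one change at this position they cannot say whether any other group would bring the number below that of compound 2.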